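The source may hold more compounds than are shown below. What is called first, only, known or untested is meant among the compounds shown, and "the series" means these compounds.

Measured so far:
compound 1, `CN(C)CCn1cnnc1-c1cc(Oc2ccc(NC(=O)N/N=C/c3ccc(F)cc3F)cc2F)ccn1`: 810 nM
compound 2, `CN(C)CCn1cnnc1-c1cc(Oc2ccc(NC(=O)N/N=C/c3c(O)ccc4ccccc34)cc2F)ccn1`: 2020 nM

For the measured compounds named here, in a functional assay on MKN-45 cells (Homo sapiens) for cytotoxicity, read by MTT assay, with a stated time of 72 h (a lower number here means a stronger inhibitor, a higher number a weaker inhibitor), compound 2 gives 2020 nM, the higher of the two numbers measured so far; its nearest neighbour is compound 1, which gives 810 nM in this assay. Going by the values given here, the one measured step, a 2.5-fold higher number from compound 1 to compound 2 (0.40 log units; beyond the scatter), accompanied the move from a single fluorinated ring to the two-ring hydroxynaphthyl group on the carbon with the double bond to nitrogen.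

Compound 3, `CN(C)CCn1cnnc1-c1cc(Oc2ccc(NC(=O)N/N=C/c3cccc(Br)c3)cc2F)ccn1`, has not been measured. Relative to compound 2 the change is 3-bromophenyl in place of 2-hydroxynaphthalen-1-yl on a carbon with a double bond to nitrogen. This removes the two-ring group again and puts back a single six-membered ring, now carrying bromine instead of fluorine, so it largely undoes the change that separated compound 1 from compound 2. Among the compounds with values here, only that one step bears on it, and it was modest. Because a 2.5-fold higher number from compound 1 to compound 2 (0.40 log units; beyond the scatter) went upward on entry of the larger ring, compound 3 is expected to move back down by a similar modest amount, a 2.2-fold lower number from compound 2 to compound 3 (0.35 log units; beyond the scatter), landing near the number of the difluorophenyl compound. The estimate for compound 3 in this assay is 900 nM, with a range from 400 nM to 2200 nM.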

Compound 3, half-maximal inhibitory concentration: 450 nM
Estimate against measurement, compound 3: 2.0-fold (0.30 log units) above; the range from low to high includes it.
By their numbers in this assay, from the lowest: compounds 3 and 1 (each within the scatter of the next); then compound 2.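

In this assay the exchange of 2-hydroxynaphthalen-1-yl for 3-bromophenyl on the carbon with a double bond to nitrogen gives a 4.5-fold lower number from compound 2 to compound 3 (0.65 log units; beyond the scatter) and so shows that the higher number of compound 2 is not tied to the return of one particular single-ring group. The comparison of the two single-ring compounds gives a 1.8-fold lower number from compound 1 to compound 3 (0.26 log units; within the scatter) and leaves 3-bromophenyl and 2,4-difluorophenyl unseparated at this position, although the halogen, its count and its placement on the ring all differ, so that among the three compounds only compound 2 stands apart. No measurement available here accounts for this difference.

The compounds shown do not separate the second aromatic ring of 2-hydroxynaphthalen-1-yl from its hydroxyl group, since both leave together in the step to compound 3, and a naphthalen-1-yl group without the hydroxyl or a 2-hydroxyphenyl group would be needed to tell them apart. Also open, as far as these compounds go, is whether the position accepts a ring without halogen, such as an unsubstituted phenyl, or one carrying an amine or a carboxylic acid.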